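A few compounds are considered here, and "the series" means these few. Any claim that something is new, unique, unknown or untested is made for them only; others in the source may bear on it.

Compound 1 `COc1ncc(-c2ccc3ncnc(Nc4ccc(OCCO)cc4)c3c2)cc1NS(C)(=O)=O`: 3270 nM
Compound 2 `COc1ncc(-c2ccc3ncnc(Nc4cnn(CCCO)c4)c3c2)cc1NS(C)(=O)=O`: 730 nM
Compound 3 `COc1ncc(-c2ccc3ncnc(Nc4ccc(OCCO)c(Cl)c4)c3c2)cc1NS(=O)(=O)c1ccc(F)cc1F`: 3740 nM

All three were tested in a functional assay on MCF7 cells (Homo sapiens) for antiproliferative activity, read by sulforhodamine B assay, with a stated time of 72 h; on this read-out higher numbers stand for weaker inhibition and lower numbers for stronger inhibition. Compound 2 gives the lowest number of the three; compound 3 gives the highest, and compound 1 sits close to compound 3. Among the compounds with values here, the only single-point step among them is a 4.5-fold lower number from compound 1 to compound 2 (0.65 log units; beyond the scatter), which concerns the group on the aromatic nitrogen and not the end of the chain.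

Compound 4 `COC(=O)CCn1cc(Nc2ncnc3ccc(-c4cnc(OC)c(NS(C)(=O)=O)c4)cc23)cn1` differs from compound 2 by methoxycarbonyl in place of hydroxymethyl on a saturated chain carbon, two bonds along the chain from an aromatic nitrogen. Within the data shown here, no measured step touches the end of this chain, so nothing beyond the scatter is expected, with a slight rise estimated: a 1.4-fold higher number from compound 2 to compound 4 (0.14 log units; within the scatter). Compound 4 is therefore expected to give about 1000 nM in this assay, within a range of 400 nM to 2500 nM.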

Compound 4, half-maximal inhibitory concentration: 490 nM
For compound 4 the middle estimate is 2.0-fold (0.31 log units) above the measured one; low and high end bracket the measured number.
By their numbers in this assay, from the lowest: compounds 4 and 2 (each within the scatter of the next); then compounds 1 and 3 (each within the scatter of the next).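

In this assay the end of this chain accepts methoxycarbonyl in place of hydroxymethyl with a 1.5-fold lower number from compound 2 to compound 4 (0.17 log units; within the scatter), so a hydrogen-bond donor at this end is not required for a number in this range. The exchange of 4-(2-hydroxyethoxy)phenyl for 1-(2-(methoxycarbonyl)ethyl)-1H-pyrazol-4-yl gives a 6.7-fold lower number from compound 1 to compound 4 (0.82 log units; beyond the scatter), which shows that the gain over compound 1 persists with either chain end on the pyrazole. Nothing measured here accounts for this outcome.

The compounds shown leave open how a carboxylic acid, a primary amide or an amine at this chain end would read. They also leave open whether a longer chain would stay within the scatter of compound 2 and compound 4.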